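Methyl in place of fluoro, starting from a limit

The source may hold more compounds than are shown below. What is called first, only, known or untested is meant among the compounds shown, and "the series" means these compounds.

Compound 1 `COc1cc(-c2nnc3n2NC(c2ccco2)C(C(=O)c2ccccc2C)S3)cc(OC)c1OC` gives 63000 nM in a functional assay on HepG2 cells (Homo sapiens) for cytotoxicity, read by MTT assay, with a stated time of 48 h; on this read-out lower numbers stand for stronger inhibition and higher numbers for weaker inhibition. Compound 2 `COc1cc(-c2nnc3n2NC(c2ccco2)C(C(=O)c2cccs2)S3)cc(OC)c1OC` gives 64100 nM in this assay. Compound 3 `COc1cc(-c2nnc3n2NC(c2ccco2)C(C(=O)c2ccc(F)cc2)S3)cc(OC)c1OC` reaches only > 100000 nM in this assay, a limit of the assay rather than a number.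

Compound 3 therefore stands at the limit of > 100000 nM in this assay, at which 1 of the 3 values shown sits, the weakest reading the assay can report. Compound 4 `COc1cc(-c2nnc3n2NC(c2ccco2)C(C(=O)c2ccc(C)cc2)S3)cc(OC)c1OC` differs from it by methyl in place of fluoro on an aromatic carbon. Within the data shown here, the steps that bear on this are those changing the group on the carbonyl carbon: an at least 1.5-fold higher number from compound 1 to compound 3 (0.20 log units; that floor lies within the scatter) and an at least 1.5-fold higher number from compound 2 to compound 3 (0.19 log units; that floor lies within the scatter), with a 1.0-fold higher number from compound 1 to compound 2 (0.01 log units; within the scatter) as well, none beyond the scatter. No step larger than the scatter is expected in this assay for compound 4, and the value may again be a limit. Compound 4 is estimated at 110000 nM, between 50000 nM and 250000 nM, which is expected to mean a step that the limit leaves unreadable from compound 3 to compound 4.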

Compound 4, half-maximal inhibitory concentration: 17400 nM
For compound 4 the middle estimate is 6.3-fold (0.80 log units) above the measured one; measured number below the stated range.
By their numbers in this assay, from the lowest: compound 4; then compounds 1 and 2 (each within the scatter of the next). At a limit, above all of these: compound 3.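

In this assay, methyl in place of fluoro on the aromatic carbon para to a large group gives the first clear shift in this series: an at least 5.7-fold lower number from compound 3 to compound 4 (0.75 log units; beyond the scatter). Compound 3 carries only a limit of the assay, not a number: the limit of > 100000 nM in this assay, at which 1 of the 4 values shown sits. The 4-methylphenyl group also gives lower numbers than the other two groups on the carbonyl, with a 3.7-fold lower number from compound 2 to compound 4 (0.57 log units; beyond the scatter) and a 3.6-fold lower number from compound 1 to compound 4 (0.56 log units; beyond the scatter), so the 2-methylphenyl of compound 1 does not match it.

Still open, from the compounds shown here alone, is how far compound 3 truly lies from compound 4. Also open, going by these compounds, is whether a methoxy group, an amine or a longer chain on that same carbon would lower the number further.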